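The source may report more compounds than this note shows. Statements on the series, on what has been measured and on what is new or still open speak of the compounds shown alone.

Working notes on the series. All three measured compounds share one core and differ only in the group on the pendant aromatic ring attached to the five-membered ring. Compound 1 `COc1cc(/C=C/C(=O)c2cccc(-n3cc(-c4ccc(Cl)cc4)[nH]c3=O)c2)cc(OC)c1OC` carries chloro on that ring, and in a functional assay on KM12 cells (Homo sapiens) for inhibition (a lower number here means a stronger inhibitor of growth, a higher number a weaker inhibitor of growth), compound 1 gives 5450 nM. Compound 2 `COc1cc(/C=C/C(=O)c2cccc(-n3cc(-c4ccccc4)[nH]c3=O)c2)cc(OC)c1OC` carries hydrogen in its place, and compound 2 gives 1370 nM. Compound 3 `COc1ccc(-c2cn(-c3cccc(C(=O)/C=C/c4cc(OC)c(OC)c(OC)c4)c3)c(=O)[nH]2)cc1` carries methoxy in its place, and compound 3 gives 1420 nM. Among these three numbers compound 3 stands second highest; its nearest neighbour is compound 2, within the scatter, and its furthest is compound 1. The measured steps are a 4.0-fold lower number from compound 1 to compound 2 (0.60 log units; beyond the scatter) and a 3.8-fold lower number from compound 1 to compound 3 (0.58 log units; beyond the scatter), whereas a 1.0-fold higher number from compound 2 to compound 3 (0.02 log units; within the scatter).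

Compound 4 `COc1cc(/C=C/C(=O)c2cccc(-n3cc(-c4cc(OC)c(OC)c(OC)c4)[nH]c3=O)c2)cc(OC)c1OC` differs from compound 3 by 3,4,5-trimethoxyphenyl in place of 4-methoxyphenyl on an aromatic carbon. The step that bears on this most directly is the one in which methoxy enters the same ring: a 1.0-fold higher number from compound 2 to compound 3 (0.02 log units; within the scatter). No measured step adds further methoxy groups to that ring, so the data give no reason to expect more than a small shift. The expected step in this assay is therefore a 1.1-fold higher number from compound 3 to compound 4 (0.05 log units; within the scatter), within the scatter. Compound 4 is estimated at 1600 nM, with a range from 550 nM to 4700 nM.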

Compound 4, concentration for 50% growth inhibition: 1120 nM
Compound 4: middle estimate off by 1.4-fold (0.15 log units), on the high side; the range from low to high includes it.
By their numbers in this assay, from the lowest: compounds 4, 2 and 3 (each within the scatter of the next); then compound 1.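

At this position on the five-membered ring, the change to 3,4,5-trimethoxyphenyl is accommodated in this assay with no shift that can be told from scatter: there is a 1.3-fold lower number from compound 3 to compound 4 (0.10 log units; within the scatter) and also a 1.2-fold lower number from compound 2 to compound 4 (0.09 log units; within the scatter) for the same group in place of phenyl. Adding methoxy groups beyond the single one of compound 3 therefore leaves the number where phenyl has it, and the only separation remains that of the 4-chlorophenyl analogue, with a 4.9-fold lower number from compound 1 to compound 4 (0.69 log units; beyond the scatter) as the widest step in the set. No measurement shown explains either this flat response or the higher number of compound 1.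

On these data alone, whether the higher number of compound 1 is specific to chloro or extends to other halogens such as fluoro or bromo remains open. Also open, as far as these compounds go, is whether a different kind of group on the pendant ring, such as an amine or a carboxylic acid, would move the number beyond the scatter from that of compound 2.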